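The compounds below may be only part of what the source reports. "The series", "measured", "known", "first", "only" and "open" are said of these compounds alone.

Of the compounds shown here, three have been measured here, all built on the same core. Compound 1 `O=C(CN1CCN(C(=O)CCCCN2CCN(c3ccccc3)CC2)CC1)Nc1cccc(Cl)c1` gives 75.4% in an assay on cells (Oocyte) for inhibition of Voltage-dependent T-type calcium channel subunit alpha-1H (Homo sapiens), tested at 100 uM; on this read-out lower numbers stand for less inhibition and higher numbers for more inhibition at the one concentration tested (going by the name of the read-out). Compound 2 `CCN1CCN(CCCCC(=O)N2CCN(CC(=O)Nc3cccc(Cl)c3)CC2)CC1` gives 71.6% in this assay, and compound 3 `O=C(CN1CCN(C(=O)CCCCN2CCN(c3ccccc3)CC2)CC1)Nc1cccc(C(F)(F)F)c1` gives 53%. Within the data shown here, compound 3 thus holds the lowest of the three numbers: the single change of trifluoromethyl in place of chloro on an aromatic carbon brought a number 22.4 percentage points lower from compound 1 to compound 3 (beyond the scatter). The number of compound 3 also lies beyond the scatter from that of compound 2.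

The next compound, compound 4 `CCN1CCN(CCCCC(=O)N2CCN(CC(=O)Nc3cccc(C(F)(F)F)c3)CC2)CC1`, differs from compound 3 by ethyl in place of phenyl on an amine nitrogen in a ring. Among the measured compounds shown here, the one measured step of exactly this kind runs from compound 1 to compound 2, where the same exchange on the same amine nitrogen in a ring produced a number 3.8 percentage points lower from compound 1 to compound 2 (within the scatter), a shift that stays within the scatter. Nothing else among the measured compounds speaks to this change. On that basis the step from compound 3 to compound 4 is expected to be small, a number 3 percentage points lower from compound 3 to compound 4 (within the scatter), with no movement beyond the scatter in either direction. Compound 4 is therefore estimated to give about 50% in this assay, most likely falling between 36% and 64%.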

Compound 4, a percentage reported as inhibition, at one concentration (the size of the read-out at that concentration, not a potency): 23.6%
Beside the measured number, compound 4's estimate is 26.4 percentage points above it; measured number below the stated range.
By their numbers in this assay, from the lowest: compound 4; then compound 3; then compounds 2 and 1 (each within the scatter of the next).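

In this assay, ethyl in place of phenyl on the amine nitrogen is not a neutral exchange once trifluoromethyl sits on the aromatic carbon. It brought a number 29.4 percentage points lower from compound 3 to compound 4 (beyond the scatter), so the size of this step depends on the group elsewhere in the molecule: the same change on two cores in this assay, a number 3.8 percentage points lower (within the scatter) from compound 1 to compound 2 and a number 29.4 percentage points lower (beyond the scatter) from compound 3 to compound 4, 25.6 percentage points apart, beyond the scatter of two such steps. Read from the other side, trifluoromethyl in place of chloro costs more with ethyl on the amine nitrogen than with phenyl there, at a number 48 percentage points lower from compound 2 to compound 4 (beyond the scatter), and the gap between the two readings is the same one: the same change on two cores in this assay, a number 22.4 percentage points lower (beyond the scatter) from compound 1 to compound 3 and a number 48 percentage points lower (beyond the scatter) from compound 2 to compound 4, 25.6 percentage points apart, beyond the scatter of two such steps. The two exchanges therefore cannot be read separately on the shared core, and a step measured with chloro on the aromatic carbon did not carry over to the compounds with trifluoromethyl.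

From the compounds shown here alone, whether this dependence extends to other groups on the amine nitrogen, such as methyl, benzyl or cyclohexyl, or to fluoro or a nitrile on the aromatic carbon, remains open. The compounds also leave open what lies behind the dependence, and all four numbers come from one concentration, which says nothing about their potency.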